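Selenium series notes: chloro in place of fluoro

A few compounds are considered here, and "the series" means these few. Any claim that something is new, unique, unknown or untested is made for them only; others in the source may bear on it.

Compound 1 `CC(C)COC(=O)Nc1ccc([Se][Se]c2ccc(NC(=O)OCC(C)C)cc2)cc1` gives 29.6% in a physicochemical assay, with a stated time of 6 min, tested at 0.1 mg/mL; on this read-out lower numbers stand for less inhibition and higher numbers for more inhibition at the one concentration tested (going by the name of the read-out). Compound 2 `CCOC(=O)Nc1ccc([Se][Se]c2ccc(NC(=O)OCC)cc2)cc1` gives 21.3% in this assay, and the two numbers of compound 1 and compound 2 lie within the usual scatter of each other, so nothing can be said about an order between them. Compound 3 `N#C[Se]c1ccc(NC(=O)Oc2ccc(F)cc2)cc1` is reported in this assay only as a limit of the assay, > 25%, which is the limit of > 25% in this assay, at which 1 of the 3 values shown sits. Compound 3 therefore stands without a number of its own on this read-out; where it lies against compound 1 and compound 2 is not known from the data.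

Compound 4 `N#C[Se]c1ccc(NC(=O)Oc2ccc(Cl)cc2)cc1` differs from compound 3 by chloro in place of fluoro on an aromatic carbon. No measured pair of compounds shows a change of this kind, and no reason for a direction is available from the series. The step expected from this change in this assay is a step that the limit leaves unreadable from compound 3 to compound 4, that is, none beyond the scatter. Compound 4 is therefore expected to give about 30% in this assay, within a range from 15% to 50%, with a fair chance that the assay again reports only a limit, as it did for compound 3.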

Compound 4, a percentage reported as inhibition, at one concentration (the size of the read-out at that concentration, not a potency): > 25%
Compound 4 was reported as a limit; the forecaster's own chance of this, stated with the estimate: 40%; the middle value is on the limit's open side.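

In this assay compound 4 gives > 25%, a limit of the assay and not a number. Compound 3 is also reported only as a limit, so no step can be read between compound 3 and compound 4: the limit of > 25% in this assay, at which 2 of the 4 values shown sit.

The compounds shown leave open whether chloro in place of fluoro on an aromatic carbon changes the inhibition at all.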